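From Pyridine to Chlorophenyl on a Sulfonamide Core

A few compounds are considered here, and "the series" means these few. Any claim that something is new, unique, unknown or untested is made for them only; others in the source may bear on it.

Compound 1 `CC1CCN(C2CCN(S(=O)(=O)c3cccc(-c4ccc(F)cc4)c3)CC2)CC1`: 12 nM
Compound 2 `CC1CCN(C2CCN(S(=O)(=O)c3ccc(C#N)cc3)CC2)CC1`: 2800 nM
Compound 3 `CC1CCN(C2CCN(S(=O)(=O)c3cccnc3)CC2)CC1`: 2400 nM

In a functional assay on DLD-1 cells (Homo sapiens) for antiproliferative activity, read by CellTiter-Glo, with a stated time of 72 h (on this read-out lower numbers stand for stronger inhibition and higher numbers for weaker inhibition), compound 3 stands second highest of the three numbers; compound 2 lies within the scatter of it, while compound 1 gives a far lower number. Compound 4 `CC1CCN(C2CCN(S(=O)(=O)c3cccc(Cl)c3)CC2)CC1` differs from compound 3 by 3-chlorophenyl in place of pyridin-3-yl on a sulfonyl sulfur. Among the compounds with values here, the only measured step, a 1.2-fold lower number from compound 2 to compound 3 (0.07 log units; within the scatter), exchanges two groups of which neither is 3-chlorophenyl, so it does not bear directly on this change. Compound 1, which carries a substituted ring of carbon only on the sulfonyl sulfur, gives 12 nM, which suggests that such a ring can pull the number down sharply. A step of a 12-fold lower number from compound 3 to compound 4 (1.08 log units; beyond the scatter) is expected from this change. Compound 4 is estimated at 200 nM, within 30 nM to 1500 nM.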

Compound 4, half-maximal inhibitory concentration: > 5000 nM
Compound 4: no number, only a limit (the forecaster's own chance of this, stated with the estimate: 2%); middle value at least 25-fold (1.39 log units) from the limit.
By their numbers in this assay, from the lowest: compound 1; then compounds 3 and 2 (each within the scatter of the next). At a limit, above all of these: compound 4.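

Compound 4 reaches only a limit of the assay, > 5000 nM and not a number. A ring of carbon only on the sulfonyl sulfur therefore does not lower the number by itself: an at least 2.0-fold higher number from compound 3 to compound 4 (0.31 log units; beyond the scatter) runs against the hint from compound 1, while an at least 1.7-fold higher number from compound 2 to compound 4 (0.25 log units; that floor lies within the scatter) gives only a floor. With an at least 410-fold higher number from compound 1 to compound 4 (2.61 log units; beyond the scatter) as the largest step, the low number of compound 1 depends here on the 4-fluorophenyl group that chloro replaces.

Going by these compounds, whether an amine or a carboxylic acid in place of chloro would bring the number down remains open. On these data alone, the true value of compound 4 also remains unknown.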